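Triazole thioether series: nitrophenyl to fluorophenyl hydrazone swap

The compounds below may be only part of what the source reports. "The series", "measured", "known", "first", "only" and "open" are said of these compounds alone.

Measured compounds
- compound 1 `Clc1cccc(CSc2nnc(-c3ccncc3)n2-c2ccccc2)c1`: 11200 nM
- compound 2 `O=C(CSc1nnc(-c2ccncc2)n1-c1ccccc1)N/N=C/c1ccc([N+](=O)[O-])cc1`: 15900 nM

In a functional assay on HepG2 cells (Homo sapiens) for inhibition, read by MTT assay, with a stated time of 48 h (a lower number here means a stronger inhibitor, a higher number a weaker inhibitor), compound 1 gives 11200 nM and compound 2 gives 15900 nM. Compound 2 carries the larger of the two numbers, but the gap to compound 1 lies within the usual scatter, so on these two values neither compound can be set ahead of the other. For the measured compounds named here, no step between measured compounds is recorded, and the two structures differ in more than one place, so nothing is known here about the effect of any single change.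

Compound 3 `O=C(CSc1nnc(-c2ccncc2)n1-c1ccccc1)N/N=C/c1cccc(F)c1` follows from compound 2 by one change: 3-fluorophenyl in place of 4-nitrophenyl on a carbon with a double bond to nitrogen. The shared core is untouched. Going by the values given here, no measured pair tells how the hydrazone aryl group moves the read-out in this assay; the one available comparison, compound 1 against compound 2, shows that a quite different side chain leaves the number within the scatter. On that basis the step from compound 2 to compound 3 is expected to be no larger than the scatter, a 1.1-fold lower number from compound 2 to compound 3 (0.06 log units; within the scatter), with no direction claimed. Compound 3 is accordingly estimated at 14000 nM in this assay, with a range from 5000 nM to 40000 nM.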

Compound 3, half-maximal inhibitory concentration: 24400 nM
The estimate for compound 3 lay 1.7-fold (0.24 log units) below the measured number, within the range that was stated.
By their numbers in this assay, from the lowest: compounds 1, 2 and 3 (each within the scatter of the next, the first and the last beyond it).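

In this assay, for the compounds shown here, 3-fluorophenyl in place of 4-nitrophenyl on a carbon with a double bond to nitrogen gives a 1.5-fold higher number from compound 2 to compound 3 (0.19 log units; within the scatter), the first reading of a single change. The group that leaves has 9 heavy atoms and 2 hydrogen-bond acceptors and the group that enters has 7 heavy atoms and 0 hydrogen-bond acceptors, yet compound 2 and compound 3 cannot be told apart in this read-out, so this place tolerates that exchange of aryl groups with the shared core held constant. Nothing measured on these compounds accounts for the size of this step.

The exchange alters both the substituent and its location on the aryl ring, so the two contributions cannot be separated from this single pair. From the compounds shown here alone, whether an amine or a carboxylic acid on that aryl ring, or a longer chain in place of the aryl group, would give a step beyond the scatter remains open.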